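The source may report more compounds than this note shows. Statements on the series, on what has been measured and on what is new or still open speak of the compounds shown alone.

Within the data shown here, compound 2 `CCOC(=O)[C@H]1CC[C@H](CNC(=O)c2ccc(Cc3cc4c(cc3C)C(C)(C)CCC4(C)C)o2)CC1` is the weaker of the two compounds measured so far in an assay on isolated protein for binding affinity to Gonadotropin-releasing hormone receptor (Rattus norvegicus); on this read-out lower numbers stand for stronger inhibition and higher numbers for weaker inhibition. Compound 2 gives 2730 nM, while compound 1 `Cc1cc2c(cc1Cc1ccc(C(=O)NC[C@H]3CC[C@H](C(N)=O)CC3)o1)C(C)(C)CCC2(C)C` gives 270 nM. Among the measured compounds shown here, the only measured step, a 10-fold higher number from compound 1 to compound 2 (1.00 log units; beyond the scatter), came from exchanging the amino group for an ethoxy group on the carbonyl carbon at the far end of the chain. Compound 3 `Cc1cc2c(cc1Cc1ccc(C(=O)NCC3CCC(CN)CC3)o1)C(C)(C)CCC2(C)C` changes that same end of the molecule once more: 4-(aminomethyl)cyclohexyl in place of 4-(ethoxycarbonyl)cyclohexyl on a saturated chain carbon bound to an amide-type nitrogen, so the ester of compound 2 is replaced by a group that again carries a hydrogen-bond donor, as the amide of compound 1 does. For the measured compounds named here, with compound 1 at 270 nM as the only guide, a return toward stronger binding is expected, of roughly a 5.5-fold lower number from compound 2 to compound 3 (0.74 log units; beyond the scatter), though the new group is not the same as the amide. Compound 3 is therefore estimated at 500 nM, with a range from 100 nM to 2500 nM.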

Compound 3, inhibition constant: 730 nM
The estimate for compound 3 lay 1.5-fold (0.16 log units) below the measured number, and the stated range covers the measured number.
By their numbers in this assay, from the lowest: compound 1; then compound 3; then compound 2.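

In this assay, the far end of the chain is not tied to a single group: with 4-(aminomethyl)cyclohexyl in place of 4-(ethoxycarbonyl)cyclohexyl, there is a 3.7-fold lower number from compound 2 to compound 3 (0.57 log units; beyond the scatter), so part of the ground lost with the ester is regained. The amine does not fully match the amide, however, as the change from 4-carbamoylcyclohexyl to 4-(aminomethyl)cyclohexyl gives a 2.7-fold higher number from compound 1 to compound 3 (0.43 log units; beyond the scatter), placing the three end groups in the order amide, amine, ester from the lowest number to the highest. Nothing available explains this order.

Compound 3 is drawn without the defined stereocentres of compound 2, so the shown data do not separate the two ring arrangements of the aminomethyl compound. Going by these compounds, how a carboxylic acid or the longer 2-aminoethyl chain would rank at this position also remains open.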